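Compound 2 to Compound 4: Changing the Ring-Nitrogen Substituent

A few compounds are considered here, and "the series" means these few. Any claim that something is new, unique, unknown or untested is made for them only; others in the source may bear on it.

Compound 1 `CCCCCCCCn1cc(/C=C/C(=O)c2ccc(NC(=O)CN3CCN(c4ccccc4F)CC3)cc2)nn1`: 60300 nM
Compound 2 `CCCCCCCCCCn1cc(/C=C/C(=O)c2ccc(NC(=O)CN3CCN(C(=O)OC(C)(C)C)CC3)cc2)nn1`: 77800 nM
Compound 3 `CC(C)(C)OC(=O)N1CCN(CC(=O)Nc2ccc(C(=O)/C=C/c3cn(Cc4ccc(Br)cc4)nn3)cc2)CC1`: 25800 nM

In a functional assay on SK-N-SH cells (Homo sapiens) for inhibition, read by MTT assay (on this read-out higher numbers stand for weaker inhibition and lower numbers for stronger inhibition), compound 2 gives the highest of the three numbers. Compound 1 sits nearest, within the scatter, while compound 3 lies furthest: the step of a 3.0-fold lower number from compound 2 to compound 3 (0.48 log units; beyond the scatter) is modest and concerns 4-bromophenyl in place of nonyl. Compound 4 `CCCCCCCCCCn1cc(/C=C/C(=O)c2ccc(NC(=O)CN3CCN(c4ccccc4F)CC3)cc2)nn1` differs from compound 2 at another place: 2-fluorophenyl in place of tert-butoxycarbonyl on an amine nitrogen in a ring. Among the measured compounds shown here, no measured step covers this change on its own; compound 1 carries 2-fluorophenyl on the same ring nitrogen but also a different chain, and its number lies within the scatter of compound 2. No step beyond the scatter is therefore expected in this assay. Compound 4 is estimated at 60000 nM, between 20000 nM and 150000 nM, a step of a 1.3-fold lower number from compound 2 to compound 4 (0.11 log units; within the scatter).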

Compound 4, half-maximal inhibitory concentration: 34400 nM
The estimate for compound 4 lay 1.7-fold (0.24 log units) above the measured number, within the range that was stated.
By their numbers in this assay, from the lowest: compounds 3, 4, 1 and 2 (each within the scatter of the next, the first and the last beyond it).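

Taken alone, 2-fluorophenyl in place of tert-butoxycarbonyl on an amine nitrogen in a ring gives a 2.3-fold lower number from compound 2 to compound 4 (0.35 log units; beyond the scatter) in this assay, so the number does respond, modestly, to the group at this nitrogen. The pair differing by ethyl in place of hydrogen on the saturated chain stands at a 1.8-fold lower number from compound 1 to compound 4 (0.24 log units; within the scatter), so that chain change cannot be told from the scatter. Nothing available accounts for the step at the ring nitrogen. On these data alone, it remains open whether phenyl without fluorine, or a pyridine ring, would serve this nitrogen equally, and how 2-fluorophenyl behaves alongside the 4-bromophenyl of compound 3.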